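This account rests on a few compounds, and the source may have more. Where it says the series, first, only, none or still open, it means among the compounds named here.

Measured in a functional assay on MCF7 cells (Homo sapiens) for antiproliferative activity, read by MTT assay, with a stated time of 72 h; on this read-out lower numbers stand for stronger inhibition and higher numbers for weaker inhibition:
- Compound 1 `CC1=CC[C@H]2[C@H](CC[C@]2(C)O)C(C)(C)[C@@H]1CC[C@H]1[C@]2(C)CC[C@H](OC(=O)c3ccc(Cl)cc3)C(C)(C)O[C@H]2CC[C@@]1(C)O`: 24100 nM
- Compound 2 `CC(=O)O[C@H]1CC[C@]2(C)[C@H](CC[C@@](C)(O)[C@H]2CC[C@@H]2C(C)=CC[C@@H]3C(C)=CC[C@@H]3C2(C)C)OC1(C)C`: 43500 nM
- Compound 3 `CC1=CC[C@H]2[C@H](CC[C@]2(C)O)C(C)(C)[C@@H]1CC[C@H]1[C@]2(C)CC[C@H](OCc3ccccc3)C(C)(C)O[C@H]2CC[C@@]1(C)O`: > 50000 nM (a limit of the assay, not a number)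

Compound 2 and compound 1 lie within the usual scatter of each other, so neither can be ranked above the other. Compound 4 `CC1=CC[C@H]2[C@@H]1CC=C(C)[C@@H](CC[C@H]1[C@]3(C)CC[C@H](OCc4ccccc4)C(C)(C)O[C@H]3CC[C@@]1(C)O)C2(C)C` differs from compound 2 in one place, with benzyl in place of acetyl on an oxygen on a saturated carbon. One measured step offers a comparison, as benzyl also enters on such an oxygen there, although it replaces (4-chlorophenyl)carbonyl. Among the measured compounds shown here, since the only comparable change is an at least 2.0-fold higher number from compound 1 to compound 3 (0.31 log units; beyond the scatter), a step of similar size toward a higher number, meaning weaker inhibition, is expected in this assay. The expected step is a 2.1-fold higher number from compound 2 to compound 4 (0.32 log units; beyond the scatter). Compound 4 is estimated at 90000 nM, with an expected range of 45000 nM to 200000 nM.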

Compound 4, half-maximal inhibitory concentration: > 50000 nM
Compound 4: a limit, no number; the forecaster's own chance of this, stated with the estimate: 75%; the middle value does not contradict the limit.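

Swapping acetoxy for benzyloxy on this oxygen gives an at least 1.1-fold higher number from compound 2 to compound 4 (0.06 log units; that floor lies within the scatter) as the only reading, so it remains uncertain whether this change separates the two compounds at all. Compound 4 has only a limit of the assay, not a number. Benzyl on this oxygen now reaches that limit on a second core as well as in compound 3, which caps what can be read here: the limit of > 50000 nM in this assay, at which 2 of the 4 values shown sit. From the compounds shown here alone, whether an amine, a carboxylic acid or a longer chain on this oxygen would give a number under the limit stays open.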